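This account rests on a few compounds, and the source may have more. Where it says the series, first, only, none or still open, it means among the compounds named here.

Of the compounds shown here, three have so far been measured in an assay on isolated protein for inhibition of Polyunsaturated fatty acid 5-lipoxygenase (Homo sapiens), read by ELISA, with a stated time of 10 min; a higher number here means a weaker inhibitor, a lower number a stronger inhibitor. Compound 1 `CCCCCCCCCCCc1cc(O)cc(OC)c1O` gives 280 nM, compound 2 `COc1cc(O)cc(Br)c1O` gives 1140 nM, and compound 3 `COC1=CC(=O)C=C(Br)C1OC(C)=O` gives 170 nM. Compound 2 therefore stands highest of the three, and both other compounds lie lower by margins beyond the scatter, so compound 2 is the weakest inhibitor of the set.

Compound 4 `CCCCCc1cc(O)cc(OC)c1O` has not been measured. It differs from compound 2 by pentyl in place of bromo on an aromatic carbon. Going by the values given here, no measured pair repeats this exact change, but compound 1, which carries an undecyl chain rather than a bromo on the shared core, gives 280 nM. On that basis compound 4 is expected to give 450 nM, within a range of 180 nM to 1200 nM. The expected step is a 2.5-fold lower number from compound 2 to compound 4 (0.40 log units; beyond the scatter), toward a stronger inhibitor and modestly beyond the scatter.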

Compound 4, half-maximal inhibitory concentration: 940 nM
Compound 4: middle estimate off by 2.1-fold (0.32 log units), on the low side; the measured number falls inside the stated range.
By their numbers in this assay, from the lowest: compounds 3 and 1 (each within the scatter of the next); then compounds 4 and 2 (each within the scatter of the next).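

In this assay, pentyl in place of bromo on an aromatic carbon ortho to a hydroxy group gives a 1.2-fold lower number from compound 2 to compound 4 (0.08 log units; within the scatter) and so leaves the reading at this position unchanged. The chain length on this position does register, since hydrogen in place of hexyl on the saturated chain gives a 3.4-fold higher number from compound 1 to compound 4 (0.53 log units; beyond the scatter) and so separates the pentyl chain from the undecyl chain. Nothing shown here explains either result. The compounds shown leave open how chains of intermediate length, such as octyl, would read. They also leave open whether an amine or a carboxylic acid at the end of the chain would change the reading.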